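A few compounds are considered here, and "the series" means these few. Any claim that something is new, unique, unknown or untested is made for them only; others in the source may bear on it.

Measured so far in an ADME assay on Vero cells (Chlorocebus sabaeus) for cytotoxicity, read by resazurin assay, with a stated time of 24 h; on this read-out lower numbers stand for higher toxicity in this test and higher numbers for lower toxicity in this test:
compound 1 (`CCCCO[C@@H]1C=CC(=O)[C@@H](COC(=O)C(C)(C)C)O1`) gives 42500 nM
compound 2 (`CC(=O)OC[C@H]1O[C@H](OC(C)C)C=CC1=O`) gives 104000 nM

Compound 2 stands highest of the two at 104000 nM and compound 1 is lower at 42500 nM in a gap that lies beyond the scatter. Compound 3 (`CC(C)O[C@@H]1C=CC(=O)[C@@H](COC(=O)C(C)(C)C)O1`) departs from compound 2 by tert-butyl in place of methyl on a carbonyl carbon and thus has tert-butyl in place of methyl on a carbonyl carbon. Among the measured compounds shown here, no measured pair isolates this change, so its size remains uncertain. Compound 1 also carries tert-butyl there and gives 42500 nM but differs from compound 3 elsewhere, so it offers only a loose guide. A modest move toward a lower number in this assay is therefore expected. The step expected is a 1.7-fold lower number from compound 2 to compound 3 (0.24 log units; within the scatter) and so lies near the scatter. For compound 3 the estimated value is 60000 nM with an expected range from 25000 nM to 140000 nM in this read-out.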

Compound 3, half-maximal cytotoxic concentration: 12500 nM
The estimate for compound 3 lay 4.8-fold (0.68 log units) above the measured number; the whole stated range lies above it.
By their numbers in this assay, from the lowest: compound 3; then compound 1; then compound 2.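

In this assay the swap of methyl for tert-butyl on a carbonyl carbon now has a size of its own, read from a pair that differs only there (an 8.3-fold lower number from compound 2 to compound 3 (0.92 log units; beyond the scatter)). The tert-butyl group does not fix the number by itself, since isopropyl in place of butyl on an oxygen on a saturated carbon also moves it beyond the scatter (a 3.4-fold lower number from compound 1 to compound 3 (0.53 log units; beyond the scatter)). No evidence at hand bears on why either step has this size.

The compounds shown leave open whether the tert-butyl step would keep its size with butyl rather than isopropyl on the oxygen, as only one such pair can be read. Also open, as far as these compounds go, is how a longer chain on that carbonyl carbon, or an amine on the oxygen-bearing carbon, would fall.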